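Swapping the basic piperidine for an arylpiperazine

The compounds below may be only part of what the source reports. "The series", "measured", "known", "first", "only" and "open" are said of these compounds alone.

Compound 3 `COc1cc2c(Nc3ccc(C#N)cc3)ncnc2cc1OCCCN1CCC(N(C)C)CC1` shares its core with compound 1 `CCOC(=O)C1CCN(CCCOc2cc3ncnc(Nc4ccc(C#N)cc4)c3cc2OC)CC1` and compound 2 `COc1cc2c(Nc3ccc(C#N)cc3)ncnc2cc1OCCCN1CCc2ccccc2C1`; the three differ only in the amine at the end of the three-carbon chain. In a functional assay on HepG2 cells (Homo sapiens) for antiproliferative activity, read by MTT assay, with a stated time of 72 h (a lower number here means a stronger inhibitor, a higher number a weaker inhibitor), compound 3 gives 33600 nM, the smaller of the two numbers reported, although the step of a 1.7-fold lower number from compound 1 to compound 3 (0.23 log units; within the scatter) stays within the scatter. In this assay compound 1 gives 57700 nM. Compound 2 reaches only a limit in this assay, > 100000 nM, which is a boundary of the measurement and not a number (the limit of > 100000 nM in this assay, at which 1 of the 3 values shown sits).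

Compound 4 `COc1cc2c(Nc3ccc(C#N)cc3)ncnc2cc1OCCCN1CCN(c2ccncc2)CC1` carries a different amine at that chain position: 4-(pyridin-4-yl)piperazin-1-yl in place of 4-(dimethylamino)piperidin-1-yl on a saturated chain carbon, three bonds along the chain from an oxygen on an aromatic ring. Going by the values given here, two measured steps touch the same position. Among the compounds with values here, the step of an at least 1.7-fold higher number from compound 1 to compound 2 (0.23 log units; that floor lies within the scatter) and the step of an at least 2.9-fold lower number from compound 2 to compound 3 (0.47 log units; beyond the scatter) both set the one group that contains an aromatic ring, the tetrahydroisoquinolinyl of compound 2, at the limit, while the two saturated amines of compound 1 and compound 3 return numbers. Compound 4 brings an aromatic ring back into the terminal group, so a higher number is expected, the step of a 2.1-fold higher number from compound 3 to compound 4 (0.32 log units; beyond the scatter), with a real chance that only a limit is returned. Compound 4 is therefore estimated at 70000 nM, with a range from 25000 nM to 200000 nM.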

Compound 4, half-maximal inhibitory concentration: 12600 nM
Estimate against measurement, compound 4: 5.6-fold (0.74 log units) above; the measured number lies below the stated range.
By their numbers in this assay, from the lowest: compound 4; then compounds 3 and 1 (each within the scatter of the next). At a limit, above all of these: compound 2.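

The terminal amine at this position can lower the number and not only leave it unchanged or raise it: in this assay, 4-(pyridin-4-yl)piperazin-1-yl in place of 4-(dimethylamino)piperidin-1-yl gives a 2.7-fold lower number from compound 3 to compound 4 (0.43 log units; beyond the scatter), and in place of 4-(ethoxycarbonyl)piperidin-1-yl it gives a 4.6-fold lower number from compound 1 to compound 4 (0.66 log units; beyond the scatter). An aromatic ring in the terminal group therefore does not on its own settle the outcome, as the tetrahydroisoquinolinyl and the pyridinyl-bearing piperazine both hold one and are still separated by an at least 7.9-fold lower number from compound 2 to compound 4 (0.89 log units; beyond the scatter). That last step starts from a limit and not a number, the one reached by compound 2: the limit of > 100000 nM in this assay, at which 1 of the 4 values shown sits.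

The compounds shown do not separate the contribution of the piperazine ring from that of the pyridine ring, and a 4-phenylpiperazin-1-yl or a 4-methylpiperazin-1-yl on the same chain carbon would bear on that question. On these data alone, it also stays open whether the lower number of compound 4, 12600 nM, would hold with a longer chain between the oxygen and the 4-(pyridin-4-yl)piperazin-1-yl group.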